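Cyclobutylamino in place of 4-methylpiperidin-1-yl

The source may report more compounds than this note shows. Statements on the series, on what has been measured and on what is new or still open speak of the compounds shown alone.

Measured so far in a functional assay on A549 cells (Homo sapiens) for inhibition, read by sulforhodamine B assay, with a stated time of 72 h (a higher number here means a weaker inhibitor, a lower number a stronger inhibitor), on the shared core:
- compound 1 `Nc1sc(-c2ccc(Cl)cc2)c(-c2ccc(Cl)cc2)c1C(=O)N1CCCCC1` gives 4620 nM
- compound 2 `CC1CCN(C(=O)c2c(N)sc(-c3ccc(Cl)cc3)c2-c2ccc(Cl)cc2)CC1` gives 1750 nM

Compound 2, at 1750 nM in this assay, holds the lower of the two numbers. Compound 3 `Nc1sc(-c2ccc(Cl)cc2)c(-c2ccc(Cl)cc2)c1C(=O)NC1CCC1` is not yet measured and differs from compound 2 by cyclobutylamino in place of 4-methylpiperidin-1-yl on a carbonyl carbon in a single place. Within the data shown here, the only measured step bearing on this is a 2.6-fold lower number from compound 1 to compound 2 (0.42 log units; beyond the scatter) for methyl in place of hydrogen on a saturated ring carbon, and it is modest. Cyclobutylamino itself remains untested, so only a modest move towards a higher number is expected. An estimated 2.0-fold higher number from compound 2 to compound 3 (0.30 log units; within the scatter) is what this expectation means. Compound 3 is expected at about 3500 nM as an estimate, with 1200 nM to 10000 nM as its expected range.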

Compound 3, half-maximal inhibitory concentration: 12500 nM
Compound 3: middle estimate off by 3.6-fold (0.55 log units), on the low side; measured number outside the range, above it.
By their numbers in this assay, from the lowest: compound 2; then compound 1; then compound 3.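

In this assay the substituent on the carbonyl carbon matters more than the methyl step alone suggested: cyclobutylamino in place of 4-methylpiperidin-1-yl gives a 7.1-fold higher number from compound 2 to compound 3 (0.85 log units; beyond the scatter) and so places compound 3 above both earlier compounds. The loss also holds against the unmethylated ring, with cyclobutylamino in place of piperidin-1-yl giving a 2.7-fold higher number from compound 1 to compound 3 (0.43 log units; beyond the scatter) on the shared core. No measurement offered here accounts for this loss.

The change alters ring size and adds the amide hydrogen together, and the compounds shown cannot separate these two differences. From the compounds shown here alone, whether pyrrolidin-1-yl or cyclohexylamino on the same carbonyl carbon would sit nearer compound 2 or compound 3 remains open.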